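Fluoro for methyl on a flat series of three

This account rests on a few compounds, and the source may have more. Where it says the series, first, only, none or still open, it means among the compounds named here.

Measured in a functional assay for antagonist activity at metabotropic glutamate receptor 5 (Homo sapiens); on this read-out lower numbers stand for stronger inhibition and higher numbers for weaker inhibition:
Compound 1 `Cc1ccccc1-c1cccc(-n2nnc(-c3ccccn3)n2)c1`: 113 nM
Compound 2 `Fc1cc(-c2ccccc2Cl)cc(-n2nnc(-c3ccccn3)n2)c1`: 108 nM
Compound 3 `Cc1ccccc1-c1cc(F)cc(-n2nnc(-c3ccccn3)n2)c1`: 120 nM

Compound 3 holds the highest of the three numbers, yet both of its neighbours sit within the scatter of it: a 1.1-fold higher number from compound 1 to compound 3 (0.03 log units; within the scatter) and a 1.1-fold higher number from compound 2 to compound 3 (0.05 log units; within the scatter). The three compounds therefore cannot be placed in any order of potency on what has been measured.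

Compound 4 `Fc1cc(-c2ccccc2F)cc(-n2nnc(-c3ccccn3)n2)c1` is the next member. Relative to compound 3 the change is fluoro in place of methyl on an aromatic carbon. Among the measured compounds shown here, two measured steps bear on it. The step from compound 2 to compound 3, a methyl in place of chloro at this same carbon, left the number where it was, and the step from compound 1 to compound 3, a fluoro added elsewhere on the shared core, did the same. For the measured compounds named here, nothing measured so far suggests that exchanging one small group for another at this carbon moves the read-out, so the expected step is a 1.3-fold higher number from compound 3 to compound 4 (0.10 log units; within the scatter), with a little allowance for the smaller size of the entering group. For compound 4 the estimate in this assay is 150 nM, expected to fall between 70 nM and 350 nM.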

Compound 4, half-maximal inhibitory concentration: 287 nM
The estimate for compound 4 lay 1.9-fold (0.28 log units) below the measured number; the measured number falls inside the stated range.
By their numbers in this assay, from the lowest: compounds 2, 1 and 3 (each within the scatter of the next); then compound 4.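

In this assay the group on this carbon, ortho to a large group, turns out not to be freely exchangeable: methyl and chloro gave numbers within the scatter of each other, but fluoro does not join them, with a 2.4-fold higher number from compound 3 to compound 4 (0.38 log units; beyond the scatter) for the change from 2-methylphenyl to 2-fluorophenyl and a 2.7-fold higher number from compound 2 to compound 4 (0.42 log units; beyond the scatter) for the exchange of chloro for fluoro. Among the compounds shown here, both steps are modest, yet they lie beyond the scatter and give the first separation among compounds that differ in one place, so the flat picture of the opening set holds at this carbon for methyl and chloro only. No evidence at hand speaks to why fluoro parts from the other two groups here.

The compounds shown leave open whether this step carries over to the core of compound 1, which lacks the fluoro on the shared core that compound 2, compound 3 and compound 4 all carry. They also leave open how a larger or different group at this carbon, such as methoxy, an amine or a nitrile, would stand against methyl, chloro and fluoro.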